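Shrinking the ketone substituent in a glutamate receptor modulator series

A few compounds are considered here, and "the series" means these few. Any claim that something is new, unique, unknown or untested is made for them only; others in the source may bear on it.

Of the compounds shown here, three sharing one core have been measured in an assay on HEK293 cells for positive allosteric modulation of metabotropic glutamate receptor 3 (Rattus norvegicus), read by thallium flux, with a stated time of 2.5 min; a higher number here means a larger maximal response, a lower number a smaller maximal response. Compound 1 `Cc1c(OCCCCOc2ccc(F)c(C(=O)O)c2)ccc(C(=O)CC(C)(C)C)c1O` gives 102%, compound 2 `CCC(=O)c1ccc(OCCCCOc2ccc(F)c(C(=O)O)c2)c(C)c1O` gives 18.4%, and compound 3 `Cc1c(OCCCCOc2ccc(F)c(C(=O)O)c2)ccc(C(=O)C(C)C)c1O` gives 31.3%, the second highest of the three. Compound 4 `CC(=O)c1ccc(OCCCCOc2ccc(F)c(C(=O)O)c2)c(C)c1O` has not yet been measured; it differs from compound 3 by methyl in place of isopropyl on a carbonyl carbon, so the isopropylcarbonyl becomes an acetyl. The steps seen so far all point the same way: a number 70.7 percentage points lower from compound 1 to compound 3 (beyond the scatter), a number 83.6 percentage points lower from compound 1 to compound 2 (beyond the scatter), and a number 12.9 percentage points higher from compound 2 to compound 3 (beyond the scatter). Each removal of carbon from the group on the carbonyl lowered the response, so a further cut is expected to lower it again. Compound 4 is therefore estimated at 12%, between 2% and 28%, a step of a number 19.3 percentage points lower from compound 3 to compound 4 (beyond the scatter).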

Compound 4, largest response reached (reported as percent of maximum), in percent of the reference or control that the assay uses: 16.8%
Compound 4: the middle estimate sits 4.8 percentage points below what was measured; measured number inside the range.
By their numbers in this assay, from the lowest: compounds 4 and 2 (each within the scatter of the next); then compound 3; then compound 1.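

Cutting isopropyl down to methyl on the carbonyl carbon still lowers the maximal response (a number 14.5 percentage points lower from compound 3 to compound 4 (beyond the scatter)). Compound 2 and compound 4, however, cannot be told apart (a number 1.6 percentage points lower from compound 2 to compound 4 (within the scatter)), so the rule of less carbon, less response, holds down to compound 2 but not from there to compound 4. Almost the whole fall is already present at compound 2, leaving the full span (a number 85.2 percentage points lower from compound 1 to compound 4 (beyond the scatter)) as the largest step, and nothing shown explains this shape. Still open, going by these compounds, is whether a chain longer than neopentyl on the carbonyl carbon would raise the response further. Also open, on these data alone, is how a cyclohexyl or an amine would behave there.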